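Heteroaryl enones in this assay: furan-2-yl analogue pending

The compounds below may be only part of what the source reports. "The series", "measured", "known", "first", "only" and "open" are said of these compounds alone.

Measured compounds:
compound 1 `O=C(/C=C/c1ccsc1)c1cc(O)c(O)c([N+](=O)[O-])c1` — 41400 nM
compound 2 `O=C(/C=C/c1ccoc1)c1cc(O)c(O)c([N+](=O)[O-])c1` — 52900 nM
compound 3 `O=C(/C=C/c1cccs1)c1cc(O)c(O)c([N+](=O)[O-])c1` — 49900 nM

All three share one core and differ only in the five-membered heteroaryl ring at the end of the enone chain. In an assay on isolated protein for inhibition of Amine oxidase [flavin-containing] A (Homo sapiens), read by fluorescence (a higher number here means a weaker inhibitor, a lower number a stronger inhibitor), compound 3 stands second highest of the three numbers, but every gap is within the scatter: a 1.2-fold higher number from compound 1 to compound 3 (0.08 log units; within the scatter) and a 1.1-fold lower number from compound 2 to compound 3 (0.03 log units; within the scatter). The whole set therefore reads as one flat cluster.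

Compound 4 `O=C(/C=C/c1ccco1)c1cc(O)c(O)c([N+](=O)[O-])c1` is the next member, and its change from compound 3 is furan-2-yl in place of thiophen-2-yl on a double-bonded chain carbon bound to a double-bonded chain carbon. The most direct precedent is the same exchange of ring type at the other attachment position, a 1.3-fold higher number from compound 1 to compound 2 (0.11 log units; within the scatter), which stayed within the scatter; the move of attachment position, a 1.2-fold higher number from compound 1 to compound 3 (0.08 log units; within the scatter), did likewise. For the measured compounds named here, nothing measured so far suggests that swapping ring type or attachment point moves this assay beyond its noise.

Compound 4 is accordingly expected to give 55000 nM (range 30000 nM to 100000 nM), a step of a 1.1-fold higher number from compound 3 to compound 4 (0.04 log units; within the scatter) that is expected to stay within the scatter.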

Compound 4, half-maximal inhibitory concentration: 60500 nM
Compound 4: the middle estimate sits 1.1-fold (0.04 log units) below what was measured, within the range that was stated.
By their numbers in this assay, from the lowest: compounds 1, 3, 2 and 4 (each within the scatter of the next).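

In this assay furan-2-yl in place of thiophen-2-yl stays within the scatter (a 1.2-fold higher number from compound 3 to compound 4 (0.08 log units; within the scatter)), and the same holds for the change from furan-3-yl (a 1.1-fold higher number from compound 2 to compound 4 (0.06 log units; within the scatter)) and for the widest gap in the set (a 1.5-fold higher number from compound 1 to compound 4 (0.16 log units; within the scatter)). With oxygen and sulfur rings now seen at both attachment points, these four compounds give no ranking of the rings on a double-bonded chain carbon bound to a double-bonded chain carbon, and neither hetero atom nor attachment point gives a readable difference. No supporting measurement speaks to why this position reads so flat.

As far as these compounds go, it remains open whether an amine, a carboxylic acid or a longer chain at this place would leave the cluster. From the compounds shown here alone, all four compounds share one core, and whether the same flat reading holds with changes elsewhere on that core also remains open.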